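The compounds below may be only part of what the source reports. "The series", "measured", "known", "first", "only" and "open" are said of these compounds alone.

Compound 1 `CC(C)=CCC/C(C)=C/Cc1c(O)cc2c(c1O)C(=O)C[C@@H](c1cc(O)cc(O)c1)O2` gives 6300 nM in a functional assay on HeLa cells (Homo sapiens) for cytotoxicity, with a stated time of 72 h; a lower number here means that less compound is needed, a higher number that more compound is needed for the effect.
Compound 2 `COc1cc([C@@H]2CC(=O)c3c(cc(O)c(C/C=C(\C)C/C=C/C(C)(C)O)c3O)O2)ccc1O` gives only a limit, > 10000 nM, in this assay.

Among the measured compounds shown here, compound 1 stands as the only actual number in this assay; the second entry is the limit of > 10000 nM in this assay, at which 1 of the 2 values shown sits. Compound 3 `COc1cc([C@@H]2CC(=O)c3c(cc(O)c(C/C=C(\C)CCC=C(C)C)c3O)O2)cc(O)c1O` has not been measured. It differs from compound 1 by 3,4-dihydroxy-5-methoxyphenyl in place of 3,5-dihydroxyphenyl on a saturated ring carbon. For the measured compounds named here, no measured pair isolates this change, so no step size is known. The step of a 1.4-fold higher number from compound 1 to compound 3 (0.15 log units; within the scatter) is expected to be small, toward weaker, with a fair chance that only a limit is returned. Compound 3 is therefore estimated at 9000 nM, expected between 4000 nM and 20000 nM.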

Compound 3, half-maximal effective concentration: 7400 nM
Compound 3: the middle estimate sits 1.2-fold (0.09 log units) above what was measured; the range from low to high includes it.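

In this assay, 3,4-dihydroxy-5-methoxyphenyl in place of 3,5-dihydroxyphenyl on a saturated ring carbon gives a 1.2-fold higher number from compound 1 to compound 3 (0.07 log units; within the scatter). This position thus accepts the added methoxy and hydroxyl pattern without a change distinguishable from scatter, and the exchange returns a number, not a limit. Nothing on hand bears on a cause for this outcome. Going by these compounds, whether any group here can move the number beyond the scatter remains open. An amine or a carboxylic acid on this phenyl ring would test that.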